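The compounds below may be only part of what the source reports. "The series", "measured", "known", "first", "only" and "open" are said of these compounds alone.

Working notes on the series. Among the measured compounds shown here, compound 2 `Nc1ccccc1NC(=O)c1ccc(CSC(=S)N2CCN(Cc3cccnc3)CC2)cc1` stands highest of the two numbers so far: in a functional assay on HeLa cells (Homo sapiens) for antiproliferative activity, read by CCK-8 assay, with a stated time of 72 h, tested at 2 uM (on this read-out higher numbers stand for a stronger effect at the one concentration tested and lower numbers for a weaker effect), compound 2 gives 69.7%, while compound 1 `COc1ccc(N2CCN(C(=S)SCc3ccc(C(=O)Nc4ccccc4N)cc3)CC2)cc1` gives 39.4%. For the measured compounds named here, the single step from compound 1 to compound 2 is a number 30.3 percentage points higher from compound 1 to compound 2 (beyond the scatter), so the group on the ring nitrogen moves the read-out strongly. Compound 3 `Nc1ccccc1NC(=O)c1ccc(CSC(=S)N2CCN(C3CCCCC3)CC2)cc1` differs from compound 2 by cyclohexyl in place of (pyridin-3-yl)methyl on an amine nitrogen in a ring. Going by the values given here, no measured step covers this change directly, so expectations rest on the one step above. Compound 3 is expected to fall somewhat below compound 2, a step of about a number 14.7 percentage points lower from compound 2 to compound 3 (beyond the scatter), giving an estimate of 55% with a range from 30% to 80%.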

Compound 3, a percentage reported as inhibition, at one concentration (the size of the read-out at that concentration, not a potency): 30.6%
Beside the measured number, compound 3's estimate is 24.4 percentage points above it; the range from low to high includes it.
By their numbers in this assay, from the lowest: compounds 3 and 1 (each within the scatter of the next); then compound 2.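

On the amine nitrogen in a ring, this assay shows a number 39.1 percentage points lower from compound 2 to compound 3 (beyond the scatter) for cyclohexyl in place of (pyridin-3-yl)methyl, so the gain seen earlier is not shared by every replacement of 4-methoxyphenyl. Cyclohexyl in place of 4-methoxyphenyl gives a number 8.8 percentage points lower from compound 1 to compound 3 (within the scatter) and does not separate these two groups. Among the three groups, only (pyridin-3-yl)methyl stands apart.

From the compounds shown here alone, whether the ring nitrogen or the methylene link of that group carries the difference stays open, as does the outcome with benzyl or (pyridin-4-yl)methyl at this position. No measurement shown explains the gap.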